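This account rests on a few compounds, and the source may have more. Where it says the series, first, only, none or still open, it means among the compounds named here.

Measured so far:
compound 1, `CN(C[C@H]1Cc2c(cccc2N2C[C@@H]3C[C@H]2CN3)CN1)[C@H]1CCCc2cccnc21`, 146 nM
compound 2, `c1cnc2c(c1)CCC[C@@H]2N(CC1CCCCC1)C[C@H]1Cc2c(cccc2N2CCNCC2)CN1`, 715 nM
compound 3, `CN1CCN(c2cccc3c2C[C@H](CN(C)[C@H]2CCCc4cccnc42)N(C)C3)CC1`, 171 nM

In a functional assay on CCRF-CEM cells for antagonist activity at C-X-C chemokine receptor type 4 (Homo sapiens), read by calcium flux, with stated times of 25 min and 90 s (on this read-out higher numbers stand for weaker inhibition and lower numbers for stronger inhibition), compound 1 gives the lowest of the three numbers. Compound 3 sits closest to it, with a difference that stays within the usual scatter, so the two cannot be ranked against each other. Compound 2 lies furthest from compound 1, beyond the scatter, so compound 1 is the stronger inhibitor of that pair.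

The next compound, compound 4, is `CN(C[C@H]1Cc2c(cccc2N2C[C@H]3C[C@@H]2CN3)CN1)[C@H]1CCCc2cccnc21`. Against compound 1 the change is the two compounds have the same atoms and bonds and differ only in configuration as drawn: 2 of 4 stereo elements differ; a stereocentre at a saturated ring carbon is drawn S in compound 1 and R in compound 4; a stereocentre at a saturated ring carbon is drawn S in compound 1 and R in compound 4. Nothing enters or leaves; the two compounds are diastereomers that differ at two saturated ring carbons of the same ring.

Within the data shown here, no measured pair in this set shows what such a configurational change does in this assay, so the direction of the step has no precedent here. The working expectation is a modest move toward weaker inhibition, possibly still within the scatter, with a 1.8-fold higher number from compound 1 to compound 4 (0.25 log units; within the scatter) as the estimated step. Compound 4 is therefore expected to give about 260 nM in this assay, within a range of 80 nM to 850 nM.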

Compound 4, half-maximal inhibitory concentration: 20.7 nM
For compound 4 the middle estimate is 13-fold (1.10 log units) above the measured one, outside the stated range (below it).
By their numbers in this assay, from the lowest: compound 4; then compounds 1 and 3 (each within the scatter of the next); then compound 2.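

In this assay, among these compounds, changing the drawn configuration at two saturated ring carbons gives a 7.1-fold lower number from compound 1 to compound 4 (0.85 log units; beyond the scatter), the first step that can be read at a single place. The change in number can be assigned to stereochemistry alone, because no atom or bond differs: the fact that compounds 1 and 4 differ only in the configuration as drawn. At this ring, then, the drawn configuration alone is enough to move inhibition beyond the scatter, with the same atoms and bonds giving clearly different numbers.

On these data alone, the two stereocentres change together here, so it remains open whether one of them alone carries the step or both are required. Also open, as far as these compounds go, is whether the number of compound 4 would hold with an acetyl group or a longer alkyl chain carried on that same ring.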